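This account rests on a few compounds, and the source may have more. Where it says the series, first, only, none or still open, it means among the compounds named here.

Compound 3 `COc1ccc(CCCCCCCCOc2ccc(C[S+]([O-])c3cccc(N)c3)nc2/C=C/C(=O)O)cc1` gives the lowest number of the three in an assay for binding affinity to leukotriene B4 receptor 1 (Homo sapiens) (on this read-out lower numbers stand for stronger inhibition and higher numbers for weaker inhibition), at 4.7 nM; compound 2 `COc1ccc(CCCCCCCCOc2ccc(CSc3cccc(N)c3)nc2/C=C/C(=O)O)cc1` sits at 34 nM and compound 1 `COc1ccc(CCCCCCCCOc2ccc(C[S+]([O-])c3cccc(NS(=O)(=O)c4ccccc4)c3)nc2/C=C/C(=O)O)cc1` at 147 nM. The two measured steps, a 31-fold lower number from compound 1 to compound 3 (1.50 log units; beyond the scatter) and a 7.2-fold lower number from compound 2 to compound 3 (0.86 log units; beyond the scatter), both alter parts of the structure other than the one changed here, so neither bears directly on the present step. Compound 4 `Nc1cccc([S+]([O-])Cc2ccc(OCCCCCCCCc3ccc(C(F)(F)F)cc3)c(/C=C/C(=O)O)n2)c1` differs from compound 3 by trifluoromethyl in place of methoxy on an aromatic carbon. Going by the values given here, with no measured step at this group, the series gives nothing to scale the change by; the expected outcome is a step that stays within the scatter, a 1.3-fold higher number from compound 3 to compound 4 (0.11 log units; within the scatter). Compound 4 is therefore estimated at 6 nM, with a range from 2.5 nM to 15 nM.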

Compound 4, inhibition constant: 14 nM
Compound 4: middle estimate off by 2.3-fold (0.37 log units), on the low side, within the range that was stated.
By their numbers in this assay, from the lowest: compound 3; then compound 4; then compound 2; then compound 1.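

In this assay, going by these compounds alone, the change from 4-methoxyphenyl to 4-(trifluoromethyl)phenyl gives a 3.0-fold higher number from compound 3 to compound 4 (0.47 log units; beyond the scatter), the first measured step at this end of the molecule, so this position does respond to substitution. Methoxy is favoured over trifluoromethyl here but is not essential, as compound 4 still reads 14 nM. Nothing shown gives a reason for this step.

From the compounds shown here alone, whether a hydroxyl, a chlorine or a plain hydrogen at this carbon would read closer to compound 3 or to compound 4 remains open. Also open, going by these compounds, is whether the same step would hold with a shorter chain.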